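This account rests on a few compounds, and the source may have more. Where it says the series, first, only, none or still open, it means among the compounds named here.

Two carbamates that carry the selenocyanate group have been run in a functional assay on HT-29 cells (Homo sapiens) for cytotoxicity, read by MTT assay, with a stated time of 72 h; on this read-out higher numbers stand for lower toxicity in this test and lower numbers for higher toxicity in this test. Compound 1 `Cc1ccc(OC(=O)Nc2ccc([Se]C#N)cc2)cc1` gives 68700 nM. In this assay compound 2 `CCOC(=O)Nc1ccc([Se]C#N)cc1` gives 66600 nM, the lowest of the two numbers, though the gap to compound 1 lies within the scatter. Compound 3 `N#C[Se]c1ccc(NC(=O)Oc2ccccc2)cc1` has not been run; it differs from compound 2 by phenyl in place of ethyl on an oxygen next to a carbonyl group. Because compound 1 gives 68700 nM while also carrying an aromatic ring on the oxygen next to a carbonyl group, the expected step is none beyond the scatter, a 1.0-fold higher number from compound 2 to compound 3 (0.01 log units; within the scatter). Compound 3 is therefore estimated at 68000 nM, with a range of 40000 nM to 115000 nM.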

Compound 3, concentration lethal to 50% of the cells: 71700 nM
Estimate against measurement, compound 3: 1.1-fold (0.02 log units) below; low and high end bracket the measured number.
By their numbers in this assay, from the lowest: compounds 2, 1 and 3 (each within the scatter of the next).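

Phenyl in place of ethyl on an oxygen next to a carbonyl group gives a 1.1-fold higher number from compound 2 to compound 3 (0.03 log units; within the scatter) in this assay and thus shows directly, within one matched pair, that this swap leaves the number unchanged within the scatter. Hydrogen in place of methyl on an aromatic carbon gives a 1.0-fold higher number from compound 1 to compound 3 (0.02 log units; within the scatter) and shows that this methyl also makes no difference beyond the scatter. Nothing available explains why either change has so little effect.

Open, from the compounds shown here alone, is whether the number stays flat with an amine or a carboxylic acid in place of ethyl on this oxygen. Going by these compounds, a longer chain there also remains untested by these compounds.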